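A few compounds are considered here, and "the series" means these few. Any claim that something is new, unique, unknown or untested is made for them only; others in the source may bear on it.

Compound 1 `COc1ccc(C2CC(c3cc4ccccc4o3)=NN2C(=O)c2ccncc2)c(O)c1`: in an ADME assay on Vero cells (Chlorocebus sabaeus) for cytotoxicity, read by MTT assay, with a stated time of 72 h (on this read-out higher numbers stand for weaker inhibition and lower numbers for stronger inhibition), compound 1 gives > 190000 nM, which is a limit of the assay rather than a number.
Compound 2 `COc1ccc(C2CC(c3cc4ccccc4o3)=NN2C(=O)c2ccncc2)cc1`: in this assay compound 2 gives > 200000 nM, again a limit of the assay.

For the measured compounds named here, compound 2 thus stands at a limit, and the one other value shown is also a limit, so neither compound has a measured number. Going by the values given here, the only measured step, a step that the two limits leave unreadable from compound 1 to compound 2, is left unreadable by the two limits, the limit of > 190000 nM in this assay, at which 1 of the 2 values shown sits, and (the limit of > 200000 nM in this assay, at which 1 of the 2 values shown sits). Compound 3 `O=C(c1ccncc1)N1N=C(c2cc3ccccc3o2)CC1c1ccco1` differs from compound 2 by furan-2-yl in place of 4-methoxyphenyl on a saturated ring carbon. No readable step bears on this change. With both measured compounds sitting at limits, the expectation for compound 3 in this assay is no step beyond the scatter, and most likely another limit. Compound 3 is therefore estimated at 200000 nM, with a range from 100000 nM to 400000 nM. The expected step is a number no higher from compound 2 to compound 3 (the limit leaves the size open).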

Compound 3, half-maximal inhibitory concentration: > 208000 nM
Compound 3 ended at the assay's limit; the forecaster's own chance of this, stated with the estimate: 80%; at least 1.0-fold (0.01 log units) between middle value and limit.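

For the compounds shown here, compound 1, compound 2 and compound 3 all sit at limits of the assay, so no step between them can be read. The compounds shown leave open what actual number each would give in this assay, and whether furan-2-yl in place of 4-methoxyphenyl changes it at all.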